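From Methoxy to Chloro on a Shared Benzyl Ether Core

The source may report more compounds than this note shows. Statements on the series, on what has been measured and on what is new or still open speak of the compounds shown alone.

Three measured compounds share one core. Compound 1 `O=C(/C=C/c1ccccc1Cl)c1ccc(OCc2ccccc2)cc1` carries a 2-chlorophenyl group on the double-bonded chain, and in a functional assay on CAL-51 cells (Homo sapiens) for inhibition, read by sulforhodamine B assay, with a stated time of 3 days (a lower number here means a stronger inhibitor of growth, a higher number a weaker inhibitor of growth), compound 1 gives 7100 nM. Compound 2 `COc1cccc(/C=C/C(=O)c2ccc(OCc3ccccc3)cc2)c1` carries a 3-methoxyphenyl group in the same place; in this assay compound 2 gives 13700 nM, the second highest of the three numbers, with compound 1 nearest to it and compound 3 furthest away. Among the compounds with values here, the single step between them is a 1.9-fold higher number from compound 1 to compound 2 (0.29 log units; within the scatter). Within the data shown here, compound 3 `Cc1ccc(COc2ccc(C(=O)/C=C/c3ccccc3)cc2)cc1` differs from both in more than one place, so no single step connects it to compound 2; in this assay compound 3 gives 43200 nM.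

Compound 4 `O=C(/C=C/c1ccc(Cl)cc1)c1ccc(OCc2ccccc2)cc1` has not yet been measured. Compared with compound 2 it shows the following difference: 4-chlorophenyl in place of 3-methoxyphenyl on a double-bonded chain carbon bound to a double-bonded chain carbon. Among the measured compounds shown here, the only measured step that bears on this exchange is a 1.9-fold higher number from compound 1 to compound 2 (0.29 log units; within the scatter), in which a chlorophenyl and a methoxyphenyl traded places at the same chain carbon without leaving the scatter. On these data alone, a chlorine at a different ring position is untested here, so nothing in these numbers points to a large shift. Compound 4 is therefore expected to give about 8000 nM in this assay, with a range from 3000 nM to 25000 nM. The expected step is a 1.7-fold lower number from compound 2 to compound 4 (0.23 log units; within the scatter), judged to lie within the scatter or only slightly beyond it.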

Compound 4, concentration for 50% growth inhibition: > 50000 nM
Compound 4 gave a limit, no number; the forecaster's own chance of this, stated with the estimate: 5%; middle value at least 6.2-fold (0.79 log units) away from the limit.
By their numbers in this assay, from the lowest: compounds 1 and 2 (each within the scatter of the next); then compound 3. At a limit, above all of these: compound 4.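

Compound 4 yields only a limit of the assay, not a number: the limit of > 50000 nM in this assay, at which 1 of the 4 values shown sits. Even so, both steps read from that limit, an at least 3.6-fold higher number from compound 2 to compound 4 (0.56 log units; beyond the scatter) and an at least 7.0-fold higher number from compound 1 to compound 4 (0.84 log units; beyond the scatter), lie beyond the scatter, whereas the earlier exchange at this chain carbon, a 1.9-fold higher number from compound 1 to compound 2 (0.29 log units; within the scatter), stayed within it, so this place is not indifferent to what it carries. The second of the new steps keeps a chlorophenyl group and exchanges only 2-chlorophenyl for 4-chlorophenyl, and that single exchange separates a measured number from a limit, so swapping one chlorophenyl for the other matters here.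

Within the data shown here, how far compound 4 lies past its limit remains unknown, which leaves the true size of both steps open, and compound 3 is joined to the others by no single step, so it adds nothing about this place. Also open, on these data alone, is whether a phenyl ring carrying an amine or a carboxylic acid at this chain carbon would give a number like that of compound 1 or a limit like that of compound 4.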